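The source may hold more compounds than are shown below. What is called first, only, known or untested is meant among the compounds shown, and "the series" means these compounds.

Measured so far:
In an assay on HEK293 cells for displacement of a labelled ligand from prostaglandin D2 receptor 2 (Homo sapiens) (a lower number here means a stronger inhibitor, a higher number a weaker inhibitor), compound 1 `O=C(O)Cn1c(SCCCCOc2ccccc2)nc2ccccc21` gives 1400 nM.
In this assay compound 2 `O=C(O)Cn1c(SCCNc2ccccc2)nc2ccccc21` gives 7690 nM.

Of these two numbers compound 1 holds the lower one, and the gap from compound 1 to compound 2 lies beyond the usual scatter. Compound 3 `CCCCCSc1nc2ccccc2n1CC(=O)O` comes from compound 1 by a single change: methyl in place of phenoxy on a saturated chain carbon, four bonds along the chain from a sulfur. Within the data shown here, no measured pair shows this exact change, so the expectation rests on the two values alone. The step is expected to be a modest weakening, a 3.6-fold higher number from compound 1 to compound 3 (0.55 log units; beyond the scatter), beyond the scatter. Compound 3 is therefore estimated at 5000 nM, within a range from 1500 nM to 20000 nM.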

Compound 3, half-maximal inhibitory concentration: 1240 nM
For compound 3 the middle estimate is 4.0-fold (0.61 log units) above the measured one, and the stated range ends above it.
By their numbers in this assay, from the lowest: compounds 3 and 1 (each within the scatter of the next); then compound 2.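

In this assay, replacing phenoxy with methyl gives a 1.1-fold lower number from compound 1 to compound 3 (0.05 log units; within the scatter), so at this position the aromatic ring and oxygen of phenoxy are not needed to keep the number of compound 1. The plain chain of compound 3 also stands clearly apart from the anilino-bearing chain, with a 6.2-fold lower number from compound 2 to compound 3 (0.79 log units; beyond the scatter), though that step replaces anilino with propyl and does not isolate one atom or ring. Nothing measured here explains either step. Still open, from the compounds shown here alone, is whether a longer chain, or an amine at the chain end, would give a clearly lower number.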